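This account rests on a few compounds, and the source may have more. Where it says the series, first, only, none or still open, it means among the compounds named here.

Compound 2, with the structure `CN1CCC(Oc2ccc(Cl)cc2NC(=O)Nc2cnc(C#N)cn2)CC1`, gives 10400 nM in a functional assay on HeLa cells (Homo sapiens) for antiproliferative activity; a lower number here means that less compound is needed, a higher number that more compound is needed for the effect.
Compound 1, with the structure `N#Cc1cnc(NC(=O)Nc2cc(Cl)ccc2OC2CCOCC2)cn1`, gives > 59000 nM in this assay; this is a limit of the assay and not a number.

Compound 2 therefore stands as the only one of the two with a measured number in this assay; the other value is a limit. The move to compound 3, with the structure `CC1(COc2ccc(Cl)cc2NC(=O)Nc2cnc(C#N)cn2)COC1`, is (3-methyloxetan-3-yl)methyl in place of 1-methylpiperidin-4-yl on an oxygen on an aromatic ring. Among the compounds with values here, one measured step bears on this change: an at least 5.6-fold lower number from compound 1 to compound 2 (0.75 log units; beyond the scatter), in which the 1-methylpiperidin-4-yl group was the one entering. Compound 1 itself sits at the limit, as the limit of > 59000 nM in this assay, at which 1 of the 2 values shown sits, records. Compound 3 removes that same group again, replacing it with (3-methyloxetan-3-yl)methyl, so the gain seen in the earlier step is expected to be given back in part, as a step towards a higher number in this assay of about a 3.8-fold higher number from compound 2 to compound 3 (0.59 log units; beyond the scatter). The estimate for compound 3 in this assay is 40000 nM, with a range from 12000 nM to 120000 nM, and a real chance that only a limit is reported.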

Compound 3, half-maximal effective concentration: > 59000 nM
Compound 3 was reported as a limit (the forecaster's own chance of this, stated with the estimate: 40%); middle value at least 1.4-fold (0.16 log units) from the limit.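

Putting (3-methyloxetan-3-yl)methyl in place of 1-methylpiperidin-4-yl on the oxygen gives an at least 5.6-fold higher number from compound 2 to compound 3 (0.75 log units; beyond the scatter), so this second exchange also moves the result in this assay beyond the scatter. The first step could be read only with oxan-4-yl as the partner, whereas this one shows that the measured number is lost with a different ring, of a different size and attached through an added carbon. Among the three compounds, the only group that contains nitrogen is also the only one that gives a measured number, and no compound shown goes against this, although three compounds make a very small set. Compound 3 stands at a limit of the assay and not at a number, and the step between compound 1 and compound 3 cannot be read, so these two groups cannot be ranked against each other: the limit of > 59000 nM in this assay, at which 2 of the 3 values shown sit.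

As far as these compounds go, it remains open whether the nitrogen alone goes with the measured number, or whether the ring around it and its methyl group also matter. A piperidine ring without that methyl, an open-chain amine such as a dimethylaminoethyl group, or a carboxylic acid on the same oxygen would each test this in a different way.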